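The compounds below may be only part of what the source reports. "The series", "measured", "known", "first", "only" and "open" are said of these compounds alone.

Of the compounds shown here, two of a shared core have been tested in a functional assay on MDA-MB-231 cells (Homo sapiens) for antiproliferative activity, read by CCK-8 assay, with a stated time of 72 h; on this read-out higher numbers stand for weaker inhibition and lower numbers for stronger inhibition. Compound 1 `O=C(Nc1cccc(-c2oc3cc(-c4ccc(F)cc4)ccc3c(=O)c2O)c1)c1ccc(F)cc1` gives 16000 nM in this assay. Compound 2 `O=C(Nc1cccc(-c2oc3cc(-c4ccc(F)cc4)ccc3c(=O)c2O)c1)c1ccc(Cl)cc1` gives 12800 nM in this assay. Within the data shown here, the only change between them is chloro in place of fluoro on an aromatic carbon, and a 1.3-fold lower number from compound 1 to compound 2 (0.10 log units; within the scatter), so the two numbers cannot be told apart, and compound 2 stands at the same level as compound 1 rather than clearly apart from it.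

Compound 3 `O=C(Nc1cccc(-c2oc3cc(-c4ccc(F)cc4)ccc3c(=O)c2O)c1)c1ccc(C(F)(F)F)cc1` carries the next change in the same place: trifluoromethyl in place of chloro on an aromatic carbon. The single measured step that bears on it is the exchange of one halogen for another on this ring, which stayed within the scatter, as shown by a 1.3-fold lower number from compound 1 to compound 2 (0.10 log units; within the scatter). Nothing measured here points to a large shift in either direction, so the expected step of a 1.3-fold lower number from compound 2 to compound 3 (0.11 log units; within the scatter) is small, and the number for compound 3 is expected to stay close to that of compound 2.

Compound 3 is therefore estimated at 10000 nM, with a likely range from 4500 nM to 25000 nM in this assay.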

Compound 3, half-maximal inhibitory concentration: 29400 nM
The estimate for compound 3 lay 2.9-fold (0.47 log units) below the measured number; the whole stated range lies below it.
By their numbers in this assay, from the lowest: compounds 2, 1 and 3 (each within the scatter of the next, the first and the last beyond it).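

In this assay, this position, on a six-membered aromatic ring and para to a large group, gives its first step beyond the scatter: trifluoromethyl in place of chloro produces a 2.3-fold higher number from compound 2 to compound 3 (0.36 log units; beyond the scatter) and so points, modestly, towards weaker inhibition. The same group in place of fluoro produces a 1.8-fold higher number from compound 1 to compound 3 (0.26 log units; within the scatter) and stays within the scatter, so compound 1 cannot be told apart from either of the other two, and only compound 2 and compound 3 separate from each other. Nothing available here explains why the exchange of chloro for trifluoromethyl gives a step that can be read while the exchange of fluoro for trifluoromethyl does not.

The compounds shown carry only fluoro, chloro and trifluoromethyl at this carbon, which leaves open how an amine, a methoxy group, a carboxylic acid or a longer alkyl chain would behave there. They also leave open whether any change at this position can move the number well away from the narrow band these three compounds occupy.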